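Methoxy to ethoxy on the carbonyl: compound 4

The source may hold more compounds than are shown below. What is called first, only, known or untested is meant among the compounds shown, and "the series" means these compounds.

In a functional assay on the whole organism for agonist activity, with Mus musculus as the target (a higher number here means that more compound is needed for the effect, a lower number that less compound is needed), compound 2 (`COC(=O)N(C)CC#CCN1CCCC1`) reads 3 mg/kg and holds the middle of three numbers. Compound 1 (`CC(=O)N(C)CC#CCN1CCCC1`) lies lower with 0.55 mg/kg as its value, and compound 3 (`COC(=O)N(C)CC#CCN(C)C`) lies higher with 9.7 mg/kg as its value.

Compound 4 (`CCOC(=O)N(C)CC#CCN1CCCC1`) turns methoxy into ethoxy, with methyl in place of hydrogen on a saturated chain carbon bound to an oxygen next to a carbonyl group.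

Among the compounds with values here, two measured steps bear on this, both modest and neither making this same change. The closer one, a 5.5-fold higher number from compound 1 to compound 2 (0.74 log units; beyond the scatter), came with methoxy in place of methyl on the carbonyl carbon. The other, a 3.2-fold higher number from compound 2 to compound 3 (0.51 log units; beyond the scatter), concerns dimethylamino in place of pyrrolidin-1-yl and says little here. The size of the ethoxy step itself is unmeasured, so a modest move in the same upward direction is expected, with no move beyond the scatter still possible. The working expectation is a 2.0-fold higher number from compound 2 to compound 4 (0.30 log units; within the scatter) in the estimate. For compound 4 the estimated value is 6 mg/kg in this assay, with an expected range from 2 mg/kg to 18 mg/kg (four of five measurements).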

Compound 4, dose for half-maximal effect: > 100 mg/kg
Compound 4 gave a limit, no number (the forecaster's own chance of this, stated with the estimate: 10%); middle value at least 16-fold (1.22 log units) away from the limit.
By their numbers in this assay, from the lowest: compound 1; then compound 2; then compound 3. At a limit, above all of these: compound 4.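

The value of compound 4 is a limit of the assay, not a number: the limit of > 100 mg/kg in this assay, at which 1 of the 4 values shown sits. In this assay, within the data shown here, a methyl in place of hydrogen on a saturated chain carbon bound to an oxygen next to a carbonyl group gives an at least 33-fold higher number from compound 2 to compound 4 (1.52 log units; beyond the scatter), a large step where the earlier steps were modest. Changing only the group on the carbonyl gives an at least 180-fold higher number from compound 1 to compound 4 (2.25 log units; beyond the scatter), so the group on the carbonyl now spans the widest range in the series, and the change from methoxy to ethoxy alone takes a measurable dose to a limit.

On these data alone, it remains open whether a longer chain such as propoxy or a branched isopropoxy would read the same as ethoxy. Also open, as far as these compounds go, is how an amine on the carbonyl, such as dimethylamino in place of methoxy, would compare with compound 2.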